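Extending the Octyl Chain of a Weakly Cytotoxic Amide

The compounds below may be only part of what the source reports. "The series", "measured", "known", "first", "only" and "open" are said of these compounds alone.

Two amides sharing one core have been measured. Compound 1 `CCCCCCCCNC(=O)[C@@H](NC(=O)c1cc2ccccc2o1)[C@@H](C)O` carries a 1-benzofuran-2-yl group on a carbonyl carbon, and in a functional assay on MCF7 cells (Homo sapiens) for cytotoxicity, read by MTT assay, with a stated time of 48 h (on this read-out higher numbers stand for weaker inhibition and lower numbers for stronger inhibition), compound 1 gives 47200 nM. Compound 2 `C/C=C/C=C/C(=O)N[C@H](C(=O)NCCCCCCCC)[C@@H](C)O` has a penta-1,3-dien-1-yl group in that place, and in this assay compound 2 gives 149000 nM, the highest of the two numbers, following a 3.2-fold higher number from compound 1 to compound 2 (0.50 log units; beyond the scatter). Compound 3 `C/C=C/C=C/C(=O)N[C@H](C(=O)NCCCCCCCCCCCCCCCCCC)[C@@H](C)O` differs from compound 2 at the other end of the molecule: decyl in place of hydrogen on a saturated chain carbon, eight bonds along the chain from an amide-type nitrogen. Within the data shown here, the only measured step concerns the acyl group, not the chain, so nothing measured bears directly on this change, and no step beyond the scatter is expected in this assay for compound 3, giving an expected no change at the digits printed from compound 2 to compound 3 (within the scatter). Compound 3 is estimated at 149000 nM, within a range from 40000 nM to 500000 nM.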

Compound 3, half-maximal inhibitory concentration: 79600 nM
Beside the measured number, compound 3's estimate is 1.9-fold (0.27 log units) above it; low and high end bracket the measured number.
By their numbers in this assay, from the lowest: compounds 1, 3 and 2 (each within the scatter of the next, the first and the last beyond it).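

In this assay, decyl in place of hydrogen on a saturated chain carbon, eight bonds along the chain from an amide-type nitrogen, gives a 1.9-fold lower number from compound 2 to compound 3 (0.27 log units; within the scatter) and so leaves the number within the usual spread of repeat measurements. Among these compounds, the earlier step concerned only the acyl group, whereas this one gives the first reading at the other end of the molecule and shows that this position accepts decyl without a step beyond the scatter. No measured evidence here accounts for this result.

From the compounds shown here alone, whether a chain of intermediate length, such as butyl, or a chain ending in an amine or a carboxylic acid would read the same remains open. Also open, going by these compounds, is whether decyl at this position would give a similar reading with the 1-benzofuran-2-yl group of compound 1 on the carbonyl carbon.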